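The source may report more compounds than this note shows. Statements on the series, on what has been measured and on what is new or still open speak of the compounds shown alone.

Within the data shown here, compound 1, with the structure `COc1ccc(CSc2nnc(-c3cc([N+](=O)[O-])cc([N+](=O)[O-])c3)n2Cc2ccccc2)cc1`, is the first of two measured compounds that share one core. In an ADME assay on A-431 cells (Homo sapiens) for cytotoxicity, with a stated time of 48 h (a higher number here means a weaker inhibitor, a lower number a stronger inhibitor), compound 1 gives only a limit of the assay, > 30000 nM, and not a number. Compound 2, with the structure `COc1ccc(CSc2nnc(-c3cc([N+](=O)[O-])cc(C(F)(F)F)c3)n2Cc2ccccc2)cc1`, differs from compound 1 in that a trifluoromethyl stands in place of one nitro on an aromatic carbon. In this assay compound 2 likewise gives only a limit, > 30000 nM. The step that the two limits leave unreadable from compound 1 to compound 2 therefore cannot be read, since both values sit at the limit of > 30000 nM in this assay, at which 2 of the 2 values shown sit.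

Compound 3, with the structure `O=[N+]([O-])c1cc(-c2nnc(SCc3ccccc3)n2Cc2ccccc2)cc(C(F)(F)F)c1`, is not yet measured. It differs from compound 2 by hydrogen in place of methoxy on an aromatic carbon. Among the measured compounds shown here, the one measured step says nothing about the size of this change, and no measured step touches the methoxy at all. What the two limits do show is that every compound of this core measured so far has fallen beyond the reach of this assay. The step from compound 2 is therefore expected to be a step that the limit leaves unreadable from compound 2 to compound 3, that is, no readable change. Compound 3 is estimated at 40000 nM, between 15000 nM and 120000 nM, most likely again as a limit.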

Compound 3, half-maximal inhibitory concentration: 10100 nM
Beside the measured number, compound 3's estimate is 4.0-fold (0.60 log units) above it, and the stated range ends above it.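

In this assay, hydrogen in place of methoxy on the aromatic carbon para to a large group gives an at least 2.9-fold lower number from compound 2 to compound 3 (0.47 log units; beyond the scatter), the first step among these compounds whose direction can be read. This shows that the 4-methoxybenzyl to benzyl change can bring a compound of this core within the range of the assay, and compound 3 gives a true number, 10100 nM, which can serve as a reference point for later changes. The step sets only a minimum size, and the full size stays unknown, since compound 2 gives only a limit and not a number: the limit of > 30000 nM in this assay, at which 2 of the 3 values shown sit.

The compounds shown leave open whether it is the loss of the methoxy as such that matters, or whether other groups on this aromatic carbon, such as a fluorine, a methyl, an amine or a carboxylic acid, would give a lower or higher number than compound 3 does. They also leave open whether the same change would lower the number on compound 1, which carries a nitro where compound 2 carries a trifluoromethyl.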